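A few compounds are considered here, and "the series" means these few. Any claim that something is new, unique, unknown or untested is made for them only; others in the source may bear on it.

Working notes on the series. Compound 1 `COCCNC(=O)CCNc1ncc2c(Br)nn(-c3ccc4ncccc4c3)c2n1` has no result in an assay on SK-OV-3 cells for inhibition of eIF-2-alpha kinase GCN2 (Homo sapiens); on this read-out higher numbers stand for weaker inhibition and lower numbers for stronger inhibition; for compound 1 the entry reads "nd" (no result reported). For the measured compounds named here, compound 2 `COCCNC(=O)[C@H]1CC[C@@H](Nc2ncc3c(Br)nn(-c4ccc5ncccc5c4)c3n2)CC1` carries the only number: in this assay compound 2 gives 763 nM, so there is no second value to rank it against. Compound 3 `COCCNC(=O)[C@H]1CC[C@H](Nc2ncc3c(Br)nn(-c4ccc5ncccc5c4)c3n2)CC1` is the open question. Relative to compound 2 the change is the two compounds have the same atoms and bonds and differ only in configuration as drawn: 2 of 2 stereo elements differ (all stereocentres are inverted: mirror images); a stereocentre at a saturated ring carbon is drawn s in compound 2 and r in compound 3; a stereocentre at a saturated ring carbon is drawn s in compound 2 and r in compound 3; in words, the two compounds have the same atoms and bonds and differ only in configuration as drawn, with both stereocentres at saturated ring carbons drawn s in compound 2 and r in compound 3. Going by the values given here, no step between measured pairs exists in the set to calibrate how configuration at these ring carbons moves this assay, so the direction cannot be taken from the data; a step beyond the scatter in either direction is plausible, and the expected step of a 1.2-fold higher number from compound 2 to compound 3 (0.07 log units; within the scatter) is set near zero with a wide band. On that basis the estimate for compound 3 is 900 nM, within 150 nM to 5000 nM.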

Compound 3, half-maximal inhibitory concentration: 628 nM
Beside the measured number, compound 3's estimate is 1.4-fold (0.16 log units) above it; measured number inside the range.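

In this assay, for the compounds shown here, inverting both saturated ring carbons gives the first calibrated step at this position: a 1.2-fold lower number from compound 2 to compound 3 (0.08 log units; within the scatter). On this read-out, the drawn configuration at these two ring carbons therefore does not separate the pair, and neither compound can be ranked above the other. This comparison isolates configuration, with no group entering or leaving: the fact that compounds 2 and 3 differ only in the configuration as drawn

With no number for compound 1, the effect of replacing the saturated ring with the open chain in this assay cannot be read. The compounds shown also leave open whether a carboxylic acid or an amine in place of the amide on the ring would keep a number in this range, and whether either configuration would then matter.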